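This account rests on a few compounds, and the source may have more. Where it says the series, first, only, none or still open, it means among the compounds named here.

For the measured compounds named here, compound 2 `CCc1cccc(Nc2cc(NC(=O)Nc3cc(OC)cc(OC)c3)ncn2)c1` is one of only two compounds so far tested in a functional assay on HCC827 cells (Homo sapiens) for inhibition, read by MTT assay, with a stated time of 48 h, tested at 10 uM; on this read-out lower numbers stand for less inhibition and higher numbers for more inhibition at the one concentration tested (going by the name of the read-out). In this assay compound 2 gives 52.6%, the lower of the two numbers; compound 1 `CCc1ccc(Nc2cc(NC(=O)Nc3cc(OC)cc(OC)c3)ncn2)cc1` gives 66.2% in this assay. Going by the values given here, the one measured step between them, a number 13.6 percentage points lower from compound 1 to compound 2 (beyond the scatter), concerns the ethylphenyl group alone. Compound 3 `COc1cc(NC(=O)Nc2cc(Nc3cc(Br)ccc3OC)ncn2)cc(OC)c1` has not yet been measured in this assay. It differs from compound 2 in one place: 5-bromo-2-methoxyphenyl in place of 3-ethylphenyl on a nitrogen on an aromatic ring. Among the compounds with values here, no measured step exchanges one substituted phenyl ring for another carrying different groups, so the only guide is the step from compound 1 to compound 2, which was modest. On that basis the author expects compound 3 to stay near compound 2 and estimates a step of a number 2.6 percentage points lower from compound 2 to compound 3 (within the scatter), with wide uncertainty. Compound 3 is expected to give about 50%, within a range from 28% to 72%.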

Compound 3, a percentage reported as inhibition, at one concentration (the size of the read-out at that concentration, not a potency): 76.3%
Estimate against measurement, compound 3: 26.3 percentage points below; the measured number lies above the stated range.
By their numbers in this assay, from the lowest: compound 2; then compound 1; then compound 3.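

In this assay, the position on the nitrogen on an aromatic ring proves able to carry more than an ethylphenyl group: 5-bromo-2-methoxyphenyl in place of 3-ethylphenyl gives a number 23.7 percentage points higher from compound 2 to compound 3 (beyond the scatter), and the same group in place of 4-ethylphenyl gives a number 10.1 percentage points higher from compound 1 to compound 3 (beyond the scatter). Compound 3 therefore stands highest of the three, and a phenyl ring bearing bromine and methoxy outdoes both ethyl-bearing rings here, rather than only shifting the number between them as the move of the ethyl group did. Nothing available bears on why this exchange raises the number.

The bromine and the methoxy group enter together, so the compounds shown do not separate what each contributes. They also leave open how a dimethylamino group or a carboxylic acid on this phenyl ring would read.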